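The compounds below may be only part of what the source reports. "The series", "measured", "known", "first", "only" and "open" are said of these compounds alone.

Of the compounds shown here, three sharing one core have so far been tested in an assay on CHO cells for displacement of a labelled ligand from adenosine receptor A3 (Homo sapiens), read by scintillation counting, with a stated time of 3 h; on this read-out lower numbers stand for stronger inhibition and higher numbers for weaker inhibition. Compound 1 `COc1ccc(-c2nc3c(NC4CCCC4)ncnc3n2C)cc1` gives 1850 nM. Compound 2 `Cn1c(-c2ccccc2)nc2c(NC3CCCCC3)ncnc21` gives 2370 nM, and compound 3 `CCCn1c(-c2ccccc2)nc2c(NC3CCCCC3)ncnc21` gives 2360 nM. Compound 2 carries the highest of the three numbers, but neither gap means anything: the change a 1.0-fold lower number from compound 2 to compound 3 (0.00 log units; within the scatter) is flat, and compound 1 sits within the scatter as well, so the three compounds cannot be told apart on these values.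

Compound 4 `Cn1c(-c2ccccc2)nc2c(NC3CCC3)ncnc21` has not yet been measured. It differs from compound 2 in one place: cyclobutyl in place of cyclohexyl on a nitrogen on an aromatic ring. Among the measured compounds shown here, none of the measured steps bears on this part of the molecule. For the measured compounds named here, the only single-point step, a 1.0-fold lower number from compound 2 to compound 3 (0.00 log units; within the scatter), concerns the chain on the other aromatic nitrogen and produced no movement beyond the scatter. Compound 1 differs from compound 2 in more than one place and gives no clean reading for the ring on the nitrogen. With no guide for the cyclohexylamino to cyclobutylamino exchange, the safest expectation is no step beyond the scatter, held with wide uncertainty. Compound 4 is therefore expected to give 3000 nM, with a range from 1000 nM to 9000 nM. This estimate amounts to an expected change of a 1.3-fold higher number from compound 2 to compound 4 (0.10 log units; within the scatter).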

Compound 4, inhibition constant: 280 nM
For compound 4 the middle estimate is 11-fold (1.03 log units) above the measured one, and the stated range ends above it.
By their numbers in this assay, from the lowest: compound 4; then compounds 1, 3 and 2 (each within the scatter of the next).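

In this assay, among the compounds shown here, the group on the nitrogen on an aromatic ring proves able to move the number: cyclobutyl in place of cyclohexyl gives an 8.5-fold lower number from compound 2 to compound 4 (0.93 log units; beyond the scatter), the only step so far that lies beyond the scatter. For the compounds shown here, the one earlier step, a 1.0-fold lower number from compound 2 to compound 3 (0.00 log units; within the scatter), concerned the chain on the other aromatic nitrogen and was flat, so it gave no sign that a single change could shift this read-out at all. Neither cyclohexyl nor cyclobutyl has a hydrogen-bond donor, a hydrogen-bond acceptor or a net charge, and the listed difference between them is a four-membered carbon ring entering where a six-membered one leaves, with the smaller ring giving the lower number in this single pair.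

On these data alone, one pair cannot show whether the trend continues, so it remains open how cyclopropyl or an open chain such as isopropyl would behave on the same nitrogen, or whether cyclobutyl keeps its gain when propyl replaces methyl on the other aromatic nitrogen. No measurement at hand explains why this exchange produces so large a step.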